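This account rests on a few compounds, and the source may have more. Where it says the series, first, only, none or still open, it means among the compounds named here.

Compound 1 `[O-][n+]1nc(NCOCc2ccc(Cl)cc2)[n+]([O-])c2ccccc21` gives 2190 nM in a functional assay on A549 cells (Homo sapiens) for cytotoxicity, read by MTT assay, with a stated time of 72 h (a lower number here means a stronger inhibitor, a higher number a weaker inhibitor), the highest of the three numbers, though its gaps to compound 2 and compound 3 both stay within the scatter. Compound 2 `[O-][n+]1nc(NCOC2CCCCC2)[n+]([O-])c2ccccc21` gives 1200 nM and compound 3 `CC(C)CCOCNc1n[n+]([O-])c2ccccc2[n+]1[O-]` gives 2110 nM. Compound 4 `CCCCCCCOCNc1n[n+]([O-])c2ccccc2[n+]1[O-]` differs from compound 1 by hexyl in place of 4-chlorophenyl on a saturated chain carbon bound to an oxygen on a saturated carbon. The comparisons that bear on this are the step of a 1.0-fold lower number from compound 1 to compound 3 (0.02 log units; within the scatter), which also replaces 4-chlorophenyl with a saturated chain, and the step of a 1.8-fold higher number from compound 2 to compound 3 (0.25 log units; within the scatter), which exchanges one saturated group for another; neither moved beyond the scatter. Replacing 4-chlorophenyl with hexyl in compound 4 is therefore expected to change little, an estimated step of a 1.2-fold lower number from compound 1 to compound 4 (0.09 log units; within the scatter). Compound 4 is estimated at 1800 nM, with a range of 700 nM to 4500 nM.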

Compound 4, half-maximal inhibitory concentration: 3490 nM
The estimate for compound 4 lay 1.9-fold (0.29 log units) below the measured number; the measured number falls inside the stated range.
By their numbers in this assay, from the lowest: compounds 2, 3, 1 and 4 (each within the scatter of the next, the first and the last beyond it).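

Hexyl in place of 4-chlorophenyl gives a 1.6-fold higher number from compound 1 to compound 4 (0.20 log units; within the scatter) and so, at this place, loses the aromatic ring without a step beyond the scatter. Pentyl in place of isopropyl gives a 1.7-fold higher number from compound 3 to compound 4 (0.22 log units; within the scatter) and also stays within the scatter, whereas heptyl in place of cyclohexyl gives a 2.9-fold higher number from compound 2 to compound 4 (0.46 log units; beyond the scatter) as the only modest step beyond it so far. Nothing available accounts for that step.

Still open, on these data alone, is how an amine or a carboxylic acid would read at this place. As far as these compounds go, whether a longer chain than heptyl would widen the gap to compound 2 is also open.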